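A Bromo Swap on Compound 1

This account rests on a few compounds, and the source may have more. Where it says the series, first, only, none or still open, it means among the compounds named here.

Measured in a functional assay on HL-60 cells (Homo sapiens) for cytotoxicity, read by luminescence and CellTiter-Glo, with a stated time of 3 days; on this read-out higher numbers stand for weaker inhibition and lower numbers for stronger inhibition:
- Compound 1 `N#Cc1ccc(NC(=O)c2cc(Cc3ccccc3)ccc2O)cc1`: 1740 nM
- Compound 2 `N#Cc1ccc(NC(=O)c2cccc3cc[nH]c23)cc1`: > 10000 nM

In this assay, within the data shown here, compound 1 gives 1740 nM, and this is the only true number available so far. Compound 2 reads > 10000 nM, which is a limit of the assay and not a number. Among the measured compounds shown here, no measured step links these two compounds, so the data do not yet show what any single structural change does.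

The next compound to be tested is compound 3 `N#Cc1ccc(NC(=O)c2cc(Br)ccc2O)cc1`. It departs from compound 1 at one place: bromo in place of benzyl on an aromatic carbon. This puts bromo in place of benzyl on an aromatic carbon, para to a hydroxy group, and leaves the rest of the core of compound 1 unchanged.

For the measured compounds named here, with no measured step as a guide, the anchor is compound 1 at 1740 nM. A small move towards weaker inhibition in this assay is expected, not clearly beyond the scatter, and the estimated step is a 1.7-fold higher number from compound 1 to compound 3 (0.24 log units; within the scatter). For compound 3 the expected value is 3000 nM, with an estimated range from 1000 nM to 9000 nM.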

Compound 3, half-maximal inhibitory concentration: 620 nM
Compound 3: middle estimate off by 4.8-fold (0.68 log units), on the high side; measured number outside the range, below it.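

In this assay, bromo in place of benzyl on an aromatic carbon, para to a hydroxy group, gives a 2.8-fold lower number from compound 1 to compound 3 (0.45 log units; beyond the scatter). Among these compounds, this is the first measured step, and it shows that the six-membered aromatic ring of the benzyl group is not needed at this position for compound 3 to inhibit at least as strongly as compound 1; here the change to a single bromine atom with no ring goes with stronger inhibition. Nothing measured here bears on the reason for this step, so the result stands as an observation only.

As far as these compounds go, whether the gain belongs to bromo in particular or would also appear with another group on this carbon stays open, for instance with a methoxy group, an amine or a longer chain, since one step at one position gives no trend. Compound 2, at > 10000 nM, is a limit of the assay and not a number, and its relation to compound 1 and compound 3 cannot be read, as it differs from each in more than one place.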